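The source may hold more compounds than are shown below. What is called first, only, known or untested is meant among the compounds shown, and "the series" means these compounds.

Three compounds share one core and differ only in the group carried on the saturated chain carbon bound to the amide-type nitrogen. Compound 1 `CCN(Cc1ccc(F)cc1)C(=O)C1CCN(S(=O)(=O)c2ccc3cn[nH]c3c2)CC1` bears a 4-fluorophenyl, and in a functional assay on CHO cells for positive allosteric modulation of muscarinic acetylcholine receptor M5 (Homo sapiens), read by calcium flux (a lower number here means a smaller maximal response, a higher number a larger maximal response), compound 1 gives 55%. Compound 2 `CCN(Cc1cccc(F)c1)C(=O)C1CCN(S(=O)(=O)c2ccc3cn[nH]c3c2)CC1` bears a 3-fluorophenyl and in this assay compound 2 gives 89%. Compound 3 `CCN(Cc1cccc(Cl)c1)C(=O)C1CCN(S(=O)(=O)c2ccc3cn[nH]c3c2)CC1` bears a 3-chlorophenyl and in this assay compound 3 gives 77%. Compound 3 therefore stands second highest of the three: it lies above compound 1 by a number 22 percentage points higher from compound 1 to compound 3 (beyond the scatter) and below compound 2 by a number 12 percentage points lower from compound 2 to compound 3 (beyond the scatter).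

Compound 4 `CCN(Cc1cccc(OC)c1)C(=O)C1CCN(S(=O)(=O)c2ccc3cn[nH]c3c2)CC1` differs from compound 3 in one place: methoxy in place of chloro on an aromatic carbon. For the measured compounds named here, no measured step exchanges chloro for methoxy, so the estimate rests on what the nearby steps show. The two large movements, a number 34 percentage points higher from compound 1 to compound 2 (beyond the scatter) and a number 22 percentage points higher from compound 1 to compound 3 (beyond the scatter), both came from moving the substituent from the 4-position to the 3-position, which compound 4 retains. Going by the values given here, the only step that exchanges one substituent for another on the same aromatic carbon, a number 12 percentage points lower from compound 2 to compound 3 (beyond the scatter), was modest. The expectation is thus a step of similar size, perhaps slightly upward, a number 3 percentage points higher from compound 3 to compound 4 (within the scatter). For compound 4 the estimated value in this assay is 80%, with a range from 62% to 95%.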

Compound 4, largest response reached (reported as percent of maximum), in percent of the reference or control that the assay uses: 85%
The estimate for compound 4 lay 5 percentage points below the measured number; measured number inside the range.
By their numbers in this assay, from the lowest: compound 1; then compounds 3, 4 and 2 (each within the scatter of the next, the first and the last beyond it).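

With methoxy on this aromatic carbon, the group grows from the single heavy atom of chloro to two heavy atoms and gains a hydrogen-bond acceptor, yet this assay shows no shift beyond the scatter, with a number 8 percentage points higher from compound 3 to compound 4 (within the scatter) and with a number 4 percentage points lower from compound 2 to compound 4 (within the scatter) as well. Fluoro and chloro had stood apart at this place, but methoxy separates from neither, so the change to this third group adds no clear difference among the three compounds carrying a substituent here. The gap to the 4-fluorophenyl compound holds for this new group too, with a number 30 percentage points higher from compound 1 to compound 4 (beyond the scatter), and among the four compounds none goes against the pattern that the 3-fluorophenyl, 3-chlorophenyl and 3-methoxyphenyl compounds all lie above compound 1, although no measurement given here explains why.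

The compounds shown leave open whether this tolerance extends to a longer chain such as ethoxy, or to an amine or a carboxylic acid on the same aromatic carbon. They also leave open whether the lower number of compound 1 belongs to the place of its substituent or to the fluoro group there, as compound 1 is the only one of its kind among them.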